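The source may hold more compounds than are shown below. What is called first, only, known or untested is meant among the compounds shown, and "the series" means these compounds.

In a functional assay on DU-145 cells (Homo sapiens) for antiproliferative activity, with a stated time of 48 h (a higher number here means a weaker inhibitor, a lower number a stronger inhibitor), compound 3 (`Cc1cc(=O)c2c(O)cc(OC[C@@H]3CO3)cc2o1`) gives 7580 nM. This lies within the scatter of compound 1 (`Cc1cc(=O)c2c(OCC3CO3)cc(OCC3CO3)cc2o1`) at 7300 nM, while compound 2 (`Cc1cc(=O)c2c(OC[C@H]3CO3)cc(OC[C@H]3CO3)cc2o1`) stands apart with the higher number, 15600 nM. The next structure, compound 4 (`Cc1cc(=O)c2c(OC[C@@H]3CO3)cc(OC[C@@H]3CO3)cc2o1`), differs from compound 3 as follows: (oxiran-2-yl)methyl in place of hydrogen on an oxygen on an aromatic ring. That is, it has (oxiran-2-yl)methyl in place of hydrogen on an oxygen on an aromatic ring.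

Among the compounds with values here, no measured step covers this replacement directly. Within the data shown here, the only measured step, a 2.1-fold higher number from compound 1 to compound 2 (0.33 log units; beyond the scatter), is modest and goes with the fact that one of compounds 1 and 2 is drawn with a defined configuration and the other without, at the place where they differ. It bears on compound 4 indirectly, since compound 4 has the same atoms and bonds as compound 1 and compound 2, with both stereocentres drawn in the sense opposite to those of compound 2. Compound 1, drawn without a configuration, gives 7300 nM, so compound 4 is expected to fall near it and not to share the higher number of compound 2. No step beyond the scatter is therefore expected in this assay, though a slightly lower number is possible. The expected change is a 1.3-fold lower number from compound 3 to compound 4 (0.10 log units; within the scatter). Compound 4 is estimated at 6000 nM, with an expected range from 2500 nM to 14000 nM.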

Compound 4, half-maximal inhibitory concentration: 24500 nM
Compound 4: middle estimate off by 4.1-fold (0.61 log units), on the low side, and the stated range ends below it.
By their numbers in this assay, from the lowest: compounds 1 and 3 (each within the scatter of the next); then compounds 2 and 4 (each within the scatter of the next).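

Placing (oxiran-2-yl)methyl on the oxygen on an aromatic ring, in place of hydrogen, has a measurable cost in this assay, with both stereocentres drawn S: a 3.2-fold higher number from compound 3 to compound 4 (0.51 log units; beyond the scatter). The result also changes how the earlier stereo step reads, as a 2.1-fold higher number from compound 1 to compound 2 (0.33 log units; beyond the scatter) now has a counterpart in a 3.4-fold higher number from compound 1 to compound 4 (0.53 log units; beyond the scatter), so both forms with defined configuration stand apart from the form drawn without one, a gap that goes with: the fact that one of compounds 1 and 4 is drawn with a defined configuration and the other without, at the place where they differ. The two defined forms themselves cannot be told apart, as a 1.6-fold higher number from compound 2 to compound 4 (0.20 log units; within the scatter) stays within the scatter, so this assay shows no preference between these mirror images, whose only difference is: the fact that compounds 2 and 4 differ only in the configuration as drawn.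

From the compounds shown here alone, how much of the step on this oxygen belongs to the (oxiran-2-yl)methyl group and how much to its drawn configuration remains open. The data also do not show what separates compound 1, at 7300 nM, from both defined forms. Also open, going by these compounds, is whether a different group on this oxygen, such as a plain methyl, a longer chain, an amine or a carboxylic acid, would keep the number of compound 3, at 7580 nM.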